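From 2-iodophenyl to 3-iodophenyl on a shared core

This account rests on a few compounds, and the source may have more. Where it says the series, first, only, none or still open, it means among the compounds named here.

Of the compounds shown here, two with a shared core have been measured in a functional assay on HepG2 cells (Homo sapiens) for inhibition, read by MTT assay; on this read-out lower numbers stand for stronger inhibition and higher numbers for weaker inhibition. Compound 1 `CCc1ccc(C(=O)Nc2ccc(Nc3ncnc4cc(OC)c(OC)cc34)cc2)cc1` gives 72000 nM, while compound 2 `COc1cc2ncnc(Nc3ccc(NC(=O)c4ccccc4I)cc3)c2cc1OC` gives 33000 nM, the lower of the two numbers. For the measured compounds named here, the only measured step between them, a 2.2-fold lower number from compound 1 to compound 2 (0.34 log units; beyond the scatter), is modest and comes with 2-iodophenyl in place of 4-ethylphenyl on a carbonyl carbon.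

Compound 3 `COc1cc2ncnc(Nc3ccc(NC(=O)c4cccc(I)c4)cc3)c2cc1OC` has not yet been measured. Its difference from compound 2 is 3-iodophenyl in place of 2-iodophenyl on a carbonyl carbon. The two structures hold the same atoms, joined differently, with 3-iodophenyl in place of 2-iodophenyl on a carbonyl carbon. Going by the values given here, no measured pair shows this exact kind of change, so the single step offers only indirect guidance. Even the exchange of 4-ethylphenyl for 2-iodophenyl gave only a 2.2-fold lower number from compound 1 to compound 2 (0.34 log units; beyond the scatter), so a change in this assay no larger than that is expected, quite possibly none beyond the scatter. The expected step is a 1.2-fold higher number from compound 2 to compound 3 (0.08 log units; within the scatter), and its direction is uncertain. Compound 3 is therefore estimated at 40000 nM, with an expected range from 15000 nM to 90000 nM.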

Compound 3, half-maximal inhibitory concentration: 28000 nM
Compound 3: middle estimate off by 1.4-fold (0.15 log units), on the high side; the range from low to high includes it.
By their numbers in this assay, from the lowest: compounds 3 and 2 (each within the scatter of the next); then compound 1.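

In this assay, placing 3-iodophenyl instead of 2-iodophenyl on the carbonyl carbon gives a 1.2-fold lower number from compound 2 to compound 3 (0.07 log units; within the scatter) and so leaves the two compounds indistinguishable on this read-out. For the compounds shown here, this is the first sign that, for this pair of iodophenyl groups, the difference in how the same atoms are joined does not register in the assay. The exchange of 4-ethylphenyl for 3-iodophenyl gives a 2.6-fold lower number from compound 1 to compound 3 (0.41 log units; beyond the scatter) and is modest, so both iodophenyl compounds now stand beyond the scatter from compound 1 with lower numbers.

The compounds shown leave open whether 4-iodophenyl, or a phenyl ring carrying an amine or a carboxylic acid in place of the iodine, would give a number any different at this carbonyl carbon, and whether any group here can take the read-out far from the level these three compounds share. No supporting information bears on why these numbers fall as they do.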